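The source may report more compounds than this note shows. Statements on the series, on what has been measured and on what is new or still open speak of the compounds shown alone.

In a functional assay on A-375 cells (Homo sapiens) for cytotoxicity, read by MTT assay (a higher number here means a weaker inhibitor, a lower number a stronger inhibitor), compound 1 `C#CCOc1cc(/C=C/C(=O)c2ccc(OC)c3c2OC(C)(C)C=C3)ccc1OC` reaches only a limit, > 10000 nM. For the measured compounds named here, compound 2 `COc1ccc(/C=C/C(=O)c2ccc(OC)c3c2OC(C)(C)C=C3)cc1OC(=O)C(C)C` gives 310 nM, the only actual number so far. Going by the values given here, the single measured step, an at least 32-fold lower number from compound 1 to compound 2 (1.50 log units; beyond the scatter), is large and beyond the scatter, and one end of it rests on a limit: the limit of > 10000 nM in this assay, at which 1 of the 2 values shown sits. Among the compounds with values here, that step replaces propargyl with isopropylcarbonyl on an oxygen on an aromatic ring, so it shows only that the group on that oxygen can matter a great deal. Compound 3 `COc1ccc(/C=C/C(=O)c2ccc(OC)c3c2OC(C)(C)C=C3)cc1OC(=O)C1CC1` keeps the carbonyl and alters only what is attached to it: cyclopropyl in place of isopropyl on a carbonyl carbon. Within the data shown here, no measured step covers this exchange, and the change is far smaller than the one from propargyl, so no shift beyond the scatter is expected in this assay. The expected step is a 1.1-fold higher number from compound 2 to compound 3 (0.05 log units; within the scatter), with no firm direction. For compound 3 the estimated value is 350 nM, with an expected range from 130 nM to 1000 nM.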

Compound 3, half-maximal inhibitory concentration: 380 nM
Beside the measured number, compound 3's estimate is 1.1-fold (0.04 log units) below it; the measured number falls inside the stated range.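

In this assay, with cyclopropyl in place of isopropyl on a carbonyl carbon, the step is a 1.2-fold higher number from compound 2 to compound 3 (0.09 log units; within the scatter), so this assay does not tell the two groups apart at this position. The step of an at least 26-fold lower number from compound 1 to compound 3 (1.42 log units; beyond the scatter) is large, which shows that a second carbonyl-bearing group on the oxygen, and not isopropylcarbonyl alone, stands well apart from propargyl. Compound 1 gives > 10000 nM, which is a limit, and this step rests on it: the limit of > 10000 nM in this assay, at which 1 of the 3 values shown sits.

The compounds shown leave open whether a longer chain or an amine on that carbonyl carbon would stay in the same range as the isopropyl and cyclopropyl groups. They also leave open whether an ethyl group on that oxygen, without any carbonyl, would fall with compound 1 or with compound 3.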